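Swapping methoxy for dimethylamino on a weakly active compound

A few compounds are considered here, and "the series" means these few. Any claim that something is new, unique, unknown or untested is made for them only; others in the source may bear on it.

Compound 1 `CCCCCC(CCO)n1cnc2c(N(C)C)ncnc21` gives > 50000 nM (a limit)
Compound 2 `CCCCCCCCC(CCO)n1cnc2c(OC)ncnc21` gives 12800 nM (a number)

For the measured compounds named here, in a functional assay on HCT-116 cells (Homo sapiens) for antiproliferative activity, read by MTT assay, with a stated time of 48 h (on this read-out lower numbers stand for stronger inhibition and higher numbers for weaker inhibition), compound 2 gives 12800 nM as the only actual number so far. Compound 3 `CCCCCCCCC(CCO)n1cnc2c(N(C)C)ncnc21` differs from compound 2 at one place (dimethylamino in place of methoxy on an aromatic carbon), with dimethylamino in place of methoxy on an aromatic carbon. Going by the values given here, no measured step shows what this swap does. Compound 1, which also carries dimethylamino, gives > 50000 nM, a limit of the assay and not a number. A small change towards weaker inhibition is therefore expected, the estimated step being a 1.6-fold higher number from compound 2 to compound 3 (0.19 log units; within the scatter) in size. Compound 3 is estimated at 20000 nM (expected range 7000 nM to 50000 nM).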

Compound 3, half-maximal inhibitory concentration: 19800 nM
Beside the measured number, compound 3's estimate is 1.0-fold (0.00 log units) above it; measured number inside the range.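

In this assay, dimethylamino in place of methoxy on this aromatic carbon gives a 1.5-fold higher number from compound 2 to compound 3 (0.19 log units; within the scatter), so the two groups cannot be told apart on the longer chain. For the compounds shown here, with dimethylamino kept, propyl in place of hydrogen on a saturated chain carbon gives an at least 2.5-fold lower number from compound 1 to compound 3 (0.40 log units; beyond the scatter), the only step here beyond the scatter. Compound 1 gives a limit of the assay and not a number: the limit of > 50000 nM in this assay, at which 1 of the 3 values shown sits.

As far as these compounds go, whether a primary amine or a chlorine atom on the same aromatic carbon would behave like these two groups stays open. So does the effect of a still longer chain.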